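From phenyl to 3-cyanophenyl: a cyano group on compound 3

The source may report more compounds than this note shows. Statements on the series, on what has been measured and on what is new or still open speak of the compounds shown alone.

- compound 1 `Cn1cncc1C(O)(c1ccc(C#N)cc1)c1cc2cc([N+](=O)[O-])cc(-c3ccccc3F)c2o1`: 89.5 nM
- compound 2 `Cn1cncc1C(O)(c1ccc(C#N)cc1)c1cc2cc([N+](=O)[O-])cc(-c3ccc(F)cc3)c2o1`: 158 nM
- compound 3 `Cn1cncc1C(O)(c1ccc(C#N)cc1)c1cc2cc([N+](=O)[O-])cc(-c3ccccc3)c2o1`: 1480 nM

In a functional assay on QG-56 cells (Homo sapiens) for antiproliferative activity (a lower number here means a stronger inhibitor, a higher number a weaker inhibitor), compound 3 is the weakest of the three, at 1480 nM. Compound 4 `Cn1cncc1C(O)(c1ccc(C#N)cc1)c1cc2cc([N+](=O)[O-])cc(-c3cccc(C#N)c3)c2o1` puts cyano in place of hydrogen on an aromatic carbon, turning phenyl into 3-cyanophenyl: cyano in place of hydrogen on an aromatic carbon. For the measured compounds named here, no measured step involves cyano, so the nearest guide is fluoro. Swapping fluoro for hydrogen gave a 17-fold higher number from compound 1 to compound 3 (1.22 log units; beyond the scatter) and a 9.4-fold higher number from compound 2 to compound 3 (0.97 log units; beyond the scatter), while moving the fluoro gave a 1.8-fold higher number from compound 1 to compound 2 (0.25 log units; within the scatter). A lower number is therefore expected, though probably by a smaller margin, since cyano is a different group on a different position: a 4.2-fold lower number from compound 3 to compound 4 (0.63 log units; beyond the scatter) is the estimated step. Compound 4 is estimated at 350 nM, within a range of 80 nM to 1500 nM.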

Compound 4, half-maximal inhibitory concentration: 22.9 nM
The estimate for compound 4 lay 15-fold (1.18 log units) above the measured number, and the stated range ends above it.
By their numbers in this assay, from the lowest: compound 4; then compounds 1 and 2 (each within the scatter of the next); then compound 3.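

In this assay the cyano group gives a 65-fold lower number from compound 3 to compound 4 (1.81 log units; beyond the scatter) and so does more on this ring than either fluoro group did. It also goes past both fluoro compounds, with a 6.9-fold lower number from compound 2 to compound 4 (0.84 log units; beyond the scatter) and with a 3.9-fold lower number from compound 1 to compound 4 (0.59 log units; beyond the scatter). Nothing available explains why this group gives the lowest number of the set.

On these data alone, whether the gain comes from the cyano group itself or from its place on the ring stays open, as cyano appears at only one place here. As far as these compounds go, how an amine or a carboxylic acid on this carbon would compare is also open.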